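The compounds below may be only part of what the source reports. "The series", "measured", "known", "first", "only" and "open" are said of these compounds alone.

Working notes on the series. In a functional assay on HeLa cells (Homo sapiens) for antiproliferative activity, read by MTT assay, with a stated time of 72 h (a higher number here means a weaker inhibitor, a lower number a stronger inhibitor), compound 3 `CCOC(=O)c1cc(=O)c2cc(CSC(=S)N3CCCCC3)ccc2o1` gives 5800 nM, the lowest of the two numbers that are not limits. Compound 2 `CCOC(=O)c1cc(=O)c2cc(CSC(=S)N3CCCC3)ccc2o1` gives 6600 nM in this assay, and the step of a 1.1-fold lower number from compound 2 to compound 3 (0.06 log units; within the scatter) is within the scatter. Compound 1 `CCOC(=O)c1cc(=O)c2cc(CSC(=S)N(C(C)C)C(C)C)ccc2o1` reaches only a limit of this assay, > 25000 nM, as stated under (the limit of > 25000 nM in this assay, at which 1 of the 3 values shown sits). From it the steps of an at least 3.7-fold lower number from compound 1 to compound 2 (0.57 log units; beyond the scatter) and an at least 4.3-fold lower number from compound 1 to compound 3 (0.63 log units; beyond the scatter) are the only ones beyond the scatter. Compound 4 `CCOC(=O)c1cc(=O)c2cc(CSC(=S)N3CCOCC3)ccc2o1` differs from compound 3 by morpholin-4-yl in place of piperidin-1-yl on a thiocarbonyl carbon. For the measured compounds named here, no measured step exchanges a ring atom in this way; the nearest one, the ring-size change from compound 2 to compound 3, was within the scatter. A step of modest size or none is therefore expected, in either direction. Compound 4 is estimated at 7500 nM, between 3000 nM and 20000 nM, which means an expected step of a 1.3-fold higher number from compound 3 to compound 4 (0.11 log units; within the scatter).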

Compound 4, half-maximal inhibitory concentration: > 25000 nM
Compound 4: a limit, no number (the forecaster's own chance of this, stated with the estimate: 10%); middle value at least 3.3-fold (0.52 log units) from the limit.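

Unlike the ring-size change, which stayed within the scatter, a ring oxygen on the thiocarbonyl carbon gives a step beyond it: an at least 4.3-fold higher number from compound 3 to compound 4 (0.63 log units; beyond the scatter), and likewise an at least 3.7-fold higher number from compound 2 to compound 4 (0.57 log units; beyond the scatter). The piperidin-1-yl and pyrrolidin-1-yl groups are thus not interchangeable with morpholin-4-yl at this place in this assay. Compound 4 sits at a limit rather than a number, as does compound 1, and the step between these two cannot be read: the limit of > 25000 nM in this assay, at which 2 of the 4 values shown sit.

On these data alone, how far compound 4 lies past this limit stays open. Also open, as far as these compounds go, is whether the sulfur of thiomorpholin-4-yl or the second nitrogen of piperazin-1-yl would behave like the morpholine oxygen.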